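Fluoro in place of chloro on compound 2

The source may report more compounds than this note shows. Statements on the series, on what has been measured and on what is new or still open speak of the compounds shown alone.

Of the compounds shown here, two have numbers so far in an ADME assay on microsomes from liver (Mus musculus) for metabolic stability, read by LC-MS, using NADPH, with a stated time of 30 min, tested at 1 uM (a lower number here means that less of the compound is left, a higher number that more of the compound is left), and both keep little of the parent. Compound 1 (`C=CC(=O)Nc1cc(Nc2ncc(F)c(Nc3ccccc3S(=O)(=O)N(C)C)n2)c(OC)cc1N(C)CCN(C)C`) gives 10% in this measurement. Compound 2 (`C=CC(=O)Nc1cc(Nc2ncc(Cl)c(Nc3ccccc3S(=O)(=O)C(C)C)n2)c(OC)cc1N(C)CCN(C)C`) gives 12% in the same test, which lies within the scatter of compound 1.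

Compound 3 (`C=CC(=O)Nc1cc(Nc2ncc(F)c(Nc3ccccc3S(=O)(=O)C(C)C)n2)c(OC)cc1N(C)CCN(C)C`) differs from compound 2 in one place: fluoro in place of chloro on an aromatic carbon. Among the compounds with values here, no measured pair isolates this change. Compound 1 carries the fluoro group but differs elsewhere, and its 10% gives no sign of a shift beyond the scatter.

The expected change is a number 1 percentage points lower from compound 2 to compound 3 (within the scatter) and is estimated to stay within the scatter. Compound 3 is expected at 11% with 4% to 22% as the estimated span.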

Compound 3, percent of the compound remaining: 15%
Beside the measured number, compound 3's estimate is 4 percentage points below it, within the range that was stated.
By their numbers in this assay, from the lowest: compounds 1, 2 and 3 (each within the scatter of the next).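

In this assay the fluoro-for-chloro change can now be read on its own, on the aromatic carbon two atoms from the ring nitrogen, as a number 3 percentage points higher from compound 2 to compound 3 (within the scatter) and so gives no sign that the choice between these two halogens matters here. Isopropyl in place of dimethylamino on a sulfonyl sulfur can also be read on its own, as a number 5 percentage points higher from compound 1 to compound 3 (within the scatter) and thus also stays inside the scatter, leaving neither place with a demonstrated effect on the amount of compound left. No measurement at hand bears on why either step comes out as it does.

Going by these compounds, whether a nitrile or trifluoromethyl on this aromatic carbon would give a step beyond the scatter remains open. The same holds for a cyclopropyl or a longer chain on the sulfonyl sulfur, and the parts shared by all three compounds offer no readable step.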